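The source may report more compounds than this note shows. Statements on the series, on what has been measured and on what is new or still open speak of the compounds shown alone.

Compound 1 `Cc1cc(NCCO)nc(SCc2nc3ccccc3[nH]2)n1` is the starting point of this comparison. In a functional assay on MGC-803 cells (Homo sapiens) for cytotoxicity, read by MTT assay, with a stated time of 72 h (a lower number here means a stronger inhibitor, a higher number a weaker inhibitor), compound 1 gives > 100000 nM, which is a limit of the assay rather than a measured number. Compound 2 `Cc1cc(Nc2ccc(Br)cc2)nc(SCc2nc3ccccc3[nH]2)n1` carries a 4-bromophenyl in place of 2-hydroxyethyl on a nitrogen on an aromatic ring, and in this assay compound 2 gives 26800 nM. Among the compounds with values here, the single measured step, an at least 3.7-fold lower number from compound 1 to compound 2 (0.57 log units; beyond the scatter), is open at one side because compound 1 sits at the limit of > 100000 nM in this assay, at which 1 of the 2 values shown sits.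

Compound 3 `Cc1cc(Nc2ccc(F)cc2)nc(SCc2nc3ccccc3[nH]2)n1` has not yet been measured. It differs from compound 1 by 4-fluorophenyl in place of 2-hydroxyethyl on a nitrogen on an aromatic ring. Within the data shown here, the one measured step that bears on this change is the one from compound 1 to compound 2, where a halogen-bearing phenyl also replaced the 2-hydroxyethyl on the nitrogen on an aromatic ring; that step came out as an at least 3.7-fold lower number from compound 1 to compound 2 (0.57 log units; beyond the scatter). A step in the same direction, toward a lower number, is therefore expected for compound 3 in this assay, of roughly the size an at least 2.5-fold lower number from compound 1 to compound 3 (0.39 log units; beyond the scatter). Compound 3 is estimated to give 40000 nM in this assay, with a likely range from 15000 nM to 100000 nM.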

Compound 3, half-maximal inhibitory concentration: 5770 nM
The estimate for compound 3 lay 6.9-fold (0.84 log units) above the measured number; the whole stated range lies above it.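

The new result shows that at this nitrogen on an aromatic ring, the presence of a halogen-bearing phenyl does not alone set the outcome, since the halogen itself matters: in this assay, fluoro in place of bromo on an aromatic carbon gives a 4.6-fold lower number from compound 2 to compound 3 (0.67 log units; beyond the scatter). The change from 2-hydroxyethyl to 4-fluorophenyl gives an at least 17-fold lower number from compound 1 to compound 3 (1.23 log units; beyond the scatter), a large step in the same direction as an at least 3.7-fold lower number from compound 1 to compound 2 (0.57 log units; beyond the scatter), so both aryl groups lead to lower numbers than the 2-hydroxyethyl group. Each of these two steps stays open at one side because compound 1 has only a limit and not a measured number: the limit of > 100000 nM in this assay, at which 1 of the 3 values shown sits.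

The compounds shown cannot say whether the gap between compound 2 and compound 3 reflects a trend across halogens, as only bromo and fluoro appear, or how a chloro group or a phenyl carrying no halogen at all would compare. They also leave open why fluoro gives the lower number, and how a methoxy group on the phenyl or a longer chain ending in an amine on the same nitrogen would read in this assay.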